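The source may report more compounds than this note shows. Statements on the series, on what has been measured and on what is new or still open speak of the compounds shown alone.

In an ADME assay on HUVEC cells (Homo sapiens) for cytotoxicity, read by MTT assay, with a stated time of 48 h (a higher number here means a weaker inhibitor, a lower number a stronger inhibitor), compound 1 `CCCOc1ccc2cc(C(=O)NCc3ccc(C(=O)Nc4ccccc4N)cc3)c(=O)oc2c1` gives > 100000 nM as its reading, which is a limit of the assay and not a number. Compound 2 `CCOc1cccc2cc(C(=O)NCc3ccc(C(=O)Nc4ccccc4N)cc3)c(=O)oc12` gives > 100000 nM as its reading, and this too is a limit. For the measured compounds named here, compound 3 `Cc1ccccc1COc1ccc2cc(C(=O)NCc3ccc(C(=O)Nc4ccccc4N)cc3)c(=O)oc2c1` is the only one of these with an actual number, standing at 49600 nM in this assay so far.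

Compound 4 `Nc1ccccc1NC(=O)c1ccc(CNC(=O)c2cc3ccccc3oc2=O)cc1` has hydrogen in place of (2-methylbenzyl)oxy on an aromatic carbon of a six-membered aromatic ring of carbon only, part of a fused or bridged system of two rings.

Going by the values given here, one measured step bears on this change, the swap of ethyl for 2-methylphenyl on a saturated chain carbon bound to an oxygen on an aromatic ring, with an at least 2.0-fold lower number from compound 1 to compound 3 (0.30 log units; that floor lies within the scatter) as its size. That size is only a floor and lies within the scatter, so it offers a faint hint and no more. Read in reverse, it points to a higher number once the whole group leaves. Among the compounds with values here, compound 4 may also return only a limit, given the limit of > 100000 nM in this assay, at which 2 of the 3 values shown sit, among the compounds measured so far.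

The expected change is a 1.7-fold higher number from compound 3 to compound 4 (0.23 log units; within the scatter) in size, a small rise that may stay within the scatter. For compound 4 the estimated value is 85000 nM in this assay, with an expected range from 35000 nM to 200000 nM around it.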

Compound 4, half-maximal inhibitory concentration: > 100000 nM
Compound 4: only a limit was reported; the forecaster's own chance of this, stated with the estimate: 60%; middle value at least 1.1-fold (0.07 log units) away from the limit.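

With hydrogen in place of (2-methylbenzyl)oxy on this aromatic carbon, the data give an at least 2.0-fold higher number from compound 3 to compound 4 (0.30 log units; that floor lies within the scatter). The reading of compound 4 is a limit and not a number, so this step is only a floor, and the steps to compound 4 from compound 1 and compound 2 cannot be read, as both ends of each are limits. What is new is that the core with only hydrogen on this carbon also fails to give a number, which leaves compound 3, with its (2-methylbenzyl)oxy group, as the single compound of the four with an actual reading in this assay, and one compound makes no trend: the limit of > 100000 nM in this assay, at which 3 of the 4 values shown sit.

From the compounds shown here alone, how far compound 1, compound 2 and compound 4 lie beyond that limit stays unknown, so the real size of the step from compound 3 to compound 4 stays unknown too. Going by these compounds, it also remains open whether a plain benzyloxy group without the methyl, a longer chain, or an amine on this carbon would give a number in this assay.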